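A few compounds are considered here, and "the series" means these few. Any claim that something is new, unique, unknown or untested is made for them only; others in the source may bear on it.

Compound 2 `N#Cc1cccc(S(=O)(=O)c2cnc3c(F)cccc3c2-c2cccc(Cl)c2)c1` and compound 1 `O=S(=O)(c1ccc(F)c(Cl)c1)c1cnc2c(F)cccc2c1-c1cccc(Cl)c1` share one core and differ only at the sulfonyl sulfur: 3-chloro-4-fluorophenyl in place of 3-cyanophenyl on a sulfonyl sulfur. In an ADME assay on microsomes from liver (Homo sapiens) for metabolic stability, tested at 2.5 uM (a higher number here means faster removal of the compound, a lower number slower removal), compound 2 gives 1.11 mL/min, while compound 1 gives 0.18 mL/min, so the change produced a 6.2-fold lower number from compound 2 to compound 1 (0.79 log units; beyond the scatter). Compound 3 `N#Cc1cccc(S(=O)(=O)c2cnc3cc(F)ccc3c2-c2ccccc2F)c1` is built on a different core, and how that core differs from the core of compound 2 is not broken down here. In this assay compound 3 gives 1.39 mL/min, a number within the scatter of that of compound 2. Compound 4 `O=S(=O)(c1ccc(F)c(Cl)c1)c1cnc2cc(F)ccc2c1-c1ccccc1F` carries the same change, made on compound 3: 3-chloro-4-fluorophenyl in place of 3-cyanophenyl on a sulfonyl sulfur. The change thus occurs twice among these compounds. Because the first instance gave a 6.2-fold lower number from compound 2 to compound 1 (0.79 log units; beyond the scatter), a step of similar size is expected here, a 5.0-fold lower number from compound 3 to compound 4 (0.70 log units; beyond the scatter). Starting from the value of compound 3, 1.39 mL/min, compound 4 is estimated at 0.28 mL/min, between 0.12 mL/min and 0.7 mL/min.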

Compound 4, intrinsic clearance in a liver preparation (reported as CLH), per the amount of preparation that the assay uses: 1.07 mL/min
Compound 4: the middle estimate sits 3.8-fold (0.58 log units) below what was measured; measured number outside the range, above it.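

In this assay, placing 3-chloro-4-fluorophenyl in place of 3-cyanophenyl on a sulfonyl sulfur gave a 1.3-fold lower number from compound 3 to compound 4 (0.11 log units; within the scatter), so the large step seen on the core of compound 2 did not carry over to the core of compound 3. The two instances of the same change disagree: the same change on two cores in this assay, a 6.2-fold lower number (0.79 log units; beyond the scatter) from compound 2 to compound 1 and a 1.3-fold lower number (0.11 log units; within the scatter) from compound 3 to compound 4, 4.7-fold (0.68 log units) apart, beyond the scatter of two such steps. This shows that, in this series, the size of the step on one core did not predict its size on the other, but two pairs cannot show which difference between the cores matters or how a third core would behave.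

The compounds shown leave open how this read-out would respond if an amine or a short alkyl chain stood on the sulfonyl sulfur. They also leave open whether the step would hold with another group on either core.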